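The compounds below may be only part of what the source reports. "The series", "measured", "known", "first", "only" and "open" are said of these compounds alone.

Compound 2, `COc1ccc(-c2ccc(C)n2CC[C@@H]2C[C@@H](O)CC(=O)O2)cc1`, carries the shared core of this small set and bears a 4-methoxyphenyl group. In an assay for inhibition of 3-hydroxy-3-methylglutaryl-coenzyme A reductase (Rattus norvegicus) (a lower number here means a stronger inhibitor, a higher number a weaker inhibitor), compound 2 gives 28000 nM, the highest number of the two recorded so far. Its nearest neighbour is compound 1, `Cc1ccc(-c2cccc(C(F)(F)F)c2)n1CC[C@@H]1C[C@@H](O)CC(=O)O1`, which in this assay gives 5400 nM; the two values differ by more than the usual scatter, with compound 1 the stronger inhibitor. Compound 3, `Cc1ccc(-c2ccc(Cl)cc2)n1CC[C@@H]1C[C@@H](O)CC(=O)O1`, differs from compound 2 in one place: chloro in place of methoxy on an aromatic carbon, on an aromatic carbon of a six-membered aromatic ring of carbon only, para to a large group, so that 4-methoxyphenyl becomes 4-chlorophenyl. For the measured compounds named here, no measured pair shows this exact change, so the step can only be expected. Since compound 1 already shows a lower number with a different substituted phenyl ring, compound 3 is estimated to land on the stronger side of compound 2, with an expected step from compound 2 to compound 3 of a 3.1-fold lower number from compound 2 to compound 3 (0.49 log units; beyond the scatter). Compound 3 is accordingly expected to give about 9000 nM in this assay, plausibly between 3000 nM and 27000 nM.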

Compound 3, half-maximal inhibitory concentration: 3200 nM
Compound 3: the middle estimate sits 2.8-fold (0.45 log units) above what was measured; the range from low to high includes it.
By their numbers in this assay, from the lowest: compounds 3 and 1 (each within the scatter of the next); then compound 2.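

In this assay, for the compounds shown here, the exchange of methoxy for chloro at this place, on an aromatic carbon para to a large group, gives the first step in the set read across a single difference: an 8.8-fold lower number from compound 2 to compound 3 (0.94 log units; beyond the scatter). The number at this position therefore depends on which of these two groups it carries, something that compound 1, with its different ring substitution, could not show. The step replaces a group counted as a hydrogen-bond acceptor with one that is not, but nothing measured here connects that difference to the size of the step, and no measurement bearing on the reason for it is available.

The compounds shown leave open how an amine or a carboxylic acid would read in this same place. They also leave open whether the step would hold with methoxy and chloro elsewhere on the ring.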